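Aryl swap on the semicarbazone of a prostanoid mimic

A few compounds are considered here, and "the series" means these few. Any claim that something is new, unique, unknown or untested is made for them only; others in the source may bear on it.

Of the compounds shown here, two have been measured in a functional assay on a cell-free system (plasma) for agonist activity at thromboxane A2 receptor (Homo sapiens); a higher number here means a weaker inhibitor, a lower number a stronger inhibitor. Compound 1, `O=C(O)CCC/C=C1/C[C@H]2C[C@@H](O)[C@H](/C=N/NC(=O)Nc3ccc([N+](=O)[O-])cc3)[C@H]2C1`, gives 50 nM. Compound 2, `O=C(O)CCC/C=C1/C[C@H]2CC[C@H](/C=N/NC(=O)Nc3ccc(Cl)c(Cl)c3)[C@H]2C1`, gives 1800 nM, the highest of the two numbers; its nearest neighbour is compound 1, whose number is lower by a margin beyond the scatter, although the two differ in more than one place. Compound 3, `O=C(O)CCC/C=C1/C[C@H]2CC[C@H](/C=N/NC(=O)Nc3ccc([N+](=O)[O-])cc3)[C@H]2C1`, is not yet measured in this assay. It differs from compound 2 by 4-nitrophenyl in place of 3,4-dichlorophenyl on an amide-type nitrogen. Compound 1 carries that same 4-nitrophenyl group and gives 50 nM. A downward step beyond the scatter is therefore expected, a 9.0-fold lower number from compound 2 to compound 3 (0.95 log units; beyond the scatter). Compound 3 is estimated at 200 nM, within 50 nM to 800 nM.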

Compound 3, half-maximal inhibitory concentration: 580 nM
Compound 3: the middle estimate sits 2.9-fold (0.46 log units) below what was measured, within the range that was stated.
By their numbers in this assay, from the lowest: compound 1; then compound 3; then compound 2.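

In this assay the aryl swap now stands alone: a 3.1-fold lower number from compound 2 to compound 3 (0.49 log units; beyond the scatter) follows from 4-nitrophenyl in place of 3,4-dichlorophenyl on an amide-type nitrogen, a modest gain. The larger step belongs to the saturated ring carbon, where hydrogen in place of hydroxy gives a 12-fold higher number from compound 1 to compound 3 (1.06 log units; beyond the scatter) and so costs more than the aryl swap gains. Nothing given here explains either step.

Still open, on these data alone, is whether a methoxy or an amine on that ring carbon would match the hydroxy. As far as these compounds go, it is also open whether the hydroxy would give a similar step with 3,4-dichlorophenyl on the amide-type nitrogen.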